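Replacing pyridin-4-yl in a three-compound series

The source may hold more compounds than are shown below. What is called first, only, known or untested is meant among the compounds shown, and "the series" means these compounds.

- compound 1 (`Cc1cc2ncccc2cc1C(C)n1cnc2ncc(-c3cnn(C)c3)nc21`): "not determined" (no result reported)
- compound 2 (`CC(c1cc2cccnc2cc1F)n1cnc2ncc(-c3ccncc3)nc21`): 171 nM
- compound 3 (`CCC(c1cc2cccnc2cc1F)n1cnc2ncc(-c3ccncc3)nc21`): "not determined" (no result reported)

These results come from a functional assay on NCI-H1993 cells (Homo sapiens) for inhibition, read by CCK-8 assay, with a stated time of 72 h (on this read-out lower numbers stand for stronger inhibition and higher numbers for weaker inhibition), and only compound 2 carries a number there. For compound 3 the entry is "not determined" (no result reported) so it cannot be placed above or below compound 2, and it offers no number to start from.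

The next structure is compound 4 (`CCC(c1cc2cccnc2cc1F)n1cnc2ncc(-c3ccc(C(N)=O)c(F)c3)nc21`). The change 4-carbamoyl-3-fluorophenyl in place of pyridin-4-yl on an aromatic carbon puts 4-carbamoyl-3-fluorophenyl in place of pyridin-4-yl on an aromatic carbon of the shared core. Among the compounds with values here, no measured pair here shows what such an exchange does, so the size of the step is a judgment. With compound 2 at 171 nM as the only anchor, a step toward stronger inhibition, beyond the usual scatter, is expected in this assay but with wide uncertainty. In this assay compound 4 is expected at 40 nM (estimated range 8 nM to 200 nM).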

Compound 4, half-maximal inhibitory concentration: 226 nM
Estimate against measurement, compound 4: 5.7-fold (0.75 log units) below; measured number outside the range, above it.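

No step can be read from compound 3 to compound 4: in this assay compound 3 has the entry "not determined" (no result reported), which leaves compound 4 at 226 nM without a partner for comparison. The compounds shown leave open what exchanging pyridin-4-yl for 4-carbamoyl-3-fluorophenyl does on its own. Nothing shown here offers an explanation for the result of compound 4.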